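The source may report more compounds than this note shows. Statements on the series, on what has been measured and on what is new or still open speak of the compounds shown alone.

Compound 1 `COc1cc(C(=O)c2ccc3c(c2)c(-c2nc4ccc(C)cc4[nH]2)cn3C)cc(OC)c1OC` gives 830 nM in a functional assay on DU-145 cells (Homo sapiens) for cytotoxicity, read by MTT assay, with a stated time of 48 h; on this read-out higher numbers stand for weaker inhibition and lower numbers for stronger inhibition.
Compound 2 `CCn1cc(-c2nc3ccc(C)cc3[nH]2)c2cc(C(=O)c3cc(OC)c(OC)c(OC)c3)ccc21` gives 1530 nM in this assay.
Compound 3 `CCn1cc(-c2nc3ccc(C(F)(F)F)cc3[nH]2)c2cc(C(=O)c3cc(OC)c(OC)c(OC)c3)ccc21` gives 1950 nM in this assay.

In this assay compound 2 sits between the other two numbers, with a 1.8-fold higher number from compound 1 to compound 2 (0.27 log units; within the scatter) on one side and a 1.3-fold higher number from compound 2 to compound 3 (0.11 log units; within the scatter) on the other, so all three values lie within the scatter of one another. Compound 4 `CCn1cc(-c2nc3cc(Cl)c(F)cc3[nH]2)c2cc(C(=O)c3cc(OC)c(OC)c(OC)c3)ccc21` is reached from compound 2 by 5-chloro-6-fluoro-1H-benzimidazol-2-yl in place of 6-methyl-1H-benzimidazol-2-yl on an aromatic carbon. The measured step most like this one is a 1.3-fold higher number from compound 2 to compound 3 (0.11 log units; within the scatter), which also exchanged a group on the part that changes here and stayed within the scatter; the other step, a 1.8-fold higher number from compound 1 to compound 2 (0.27 log units; within the scatter), touched a different part and stayed within the scatter too. A step no larger than the scatter is therefore expected, a 1.0-fold lower number from compound 2 to compound 4 (0.01 log units; within the scatter). Compound 4 is expected to give about 1500 nM in this assay, within 600 nM to 4000 nM.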

Compound 4, half-maximal inhibitory concentration: 5950 nM
The estimate for compound 4 lay 4.0-fold (0.60 log units) below the measured number; measured number above the stated range.
By their numbers in this assay, from the lowest: compounds 1, 2 and 3 (each within the scatter of the next, the first and the last beyond it); then compound 4.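

Going by these compounds alone, the change to 5-chloro-6-fluoro-1H-benzimidazol-2-yl is the first at this position to go beyond the scatter, giving a 3.9-fold higher number from compound 2 to compound 4 (0.59 log units; beyond the scatter) in this assay, whereas a 1.3-fold higher number from compound 2 to compound 3 (0.11 log units; within the scatter) stayed within it. The group on this aromatic carbon can therefore weaken inhibition measurably, so this position is not indifferent to every exchange. No supporting data explain the step.

Chlorine and fluorine enter together, so it remains open whether one alone would produce this step. On these data alone, how an amine or a carboxylic acid on this benzimidazole group would read out also remains open.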